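The source may hold more compounds than are shown below. What is called first, only, known or untested is meant among the compounds shown, and "the series" means these compounds.

In an assay on HeLa cells for inhibition of sphingosine-1-phosphate transporter SPNS2 (Mus musculus), read by LC-MS, tested at 2 uM (a lower number here means less inhibition, a higher number more inhibition at the concentration tested (going by the name of the read-out)), three compounds built on one shared core have been measured. Compound 1 `CCCCCCCCCCc1ccc(-c2noc(CC3CNC3)n2)cc1` gives 63%, compound 2 `CCCCCCCCCCc1ccc(-c2noc(CN3CCNCC3)n2)cc1` gives 19%, and compound 3 `CCCCCCCCCCc1ccc(-c2noc([C@H](CCCCN)NC(C)=O)n2)cc1` gives 40%. Compound 3 therefore stands second highest of the three: its nearest neighbour is compound 2, separated by a number 21 percentage points higher from compound 2 to compound 3 (beyond the scatter), and the furthest is compound 1, separated by a number 23 percentage points lower from compound 1 to compound 3 (beyond the scatter). For the measured compounds named here, the single change from compound 1 to compound 2 brought a number 44 percentage points lower from compound 1 to compound 2 (beyond the scatter).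

Compound 4 `CCCCCCCCCCc1ccc(-c2noc(CC(O)CN3CCCC3)n2)cc1` has not been measured. It differs from compound 3 in one place: 2-hydroxy-3-(pyrrolidin-1-yl)propyl in place of 1-acetamido-5-aminopentyl on an aromatic carbon. All three measured steps exchanged the group on this same aromatic carbon, and every one of them moved the read-out beyond the scatter, so this position is clearly sensitive. Going by the values given here, none of the measured steps, however, places a 2-hydroxy-3-(pyrrolidin-1-yl)propyl group there, so its effect can only be bracketed by the spread of the three measured values. Compound 4 is therefore expected to fall near the middle of that spread, with a number 5 percentage points higher from compound 3 to compound 4 (within the scatter) as the expected step, not clearly beyond the scatter in either direction, and with wide uncertainty. For compound 4 the estimate is 45%, within a range from 20% to 70%.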

Compound 4, a percentage reported as inhibition, at one concentration (the size of the read-out at that concentration, not a potency): 21%
Compound 4: middle estimate off by 24 percentage points, on the high side; the measured number falls inside the stated range.
By their numbers in this assay, from the lowest: compounds 2 and 4 (each within the scatter of the next); then compound 3; then compound 1.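

In this assay, a number 2 percentage points higher from compound 2 to compound 4 (within the scatter) shows that 2-hydroxy-3-(pyrrolidin-1-yl)propyl on this aromatic carbon reads no differently from the (piperazin-1-yl)methyl group, so the low level seen earlier is not unique to the piperazine. The result also gives a second group that stands clearly under the azetidine compound, with a number 42 percentage points lower from compound 1 to compound 4 (beyond the scatter), and under the open-chain 1-acetamido-5-aminopentyl group, with a number 19 percentage points lower from compound 3 to compound 4 (beyond the scatter), which leaves compound 1 the highest of the four and compound 3 in an intermediate place. Nothing available explains why these groups differ in this way.

The compounds shown do not separate the contribution of the hydroxyl from that of the pyrrolidine in compound 4, a question that the same propyl chain without the hydroxyl, or a morpholine in place of the pyrrolidine, would address. They also leave open whether the value of compound 1 belongs to the azetidine itself or extends to other small rings, such as a pyrrolidin-3-yl or a piperidin-4-yl group, or to a simple primary amine on a short chain.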